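A few compounds are considered here, and "the series" means these few. Any claim that something is new, unique, unknown or untested is made for them only; others in the source may bear on it.

Measured so far:
Compound 1, `O=C(Nc1cccc(-n2cc(-c3ccncc3)c(-c3ccc(Cl)c(O)c3)n2)c1)Nc1cccc(C(F)(F)F)c1` — in a functional assay on OVCAR-8 cells (Homo sapiens) for inhibition, read by sulforhodamine B assay, with a stated time of 48 h (on this read-out lower numbers stand for stronger inhibition of growth and higher numbers for weaker inhibition of growth), compound 1 gives 1570 nM.
Compound 2, `COc1cc(-c2nn(-c3cccc(NC(=O)Nc4ccc(Cl)c(Cl)c4)c3)cc2-c2ccncc2)ccc1Cl` — in this assay compound 2 gives 931 nM.
Compound 3, `O=C(Nc1cccc(-n2cc(-c3ccncc3)c(-c3ccc(Cl)c(O)c3)n2)c1)Nc1ccc(Cl)c(Cl)c1` — in this assay compound 3 gives 1210 nM.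

All three share a core and differ only at the edges. Compound 3 and compound 1 are one change apart, (3-(trifluoromethyl)phenyl in place of 3,4-dichlorophenyl on an amide-type nitrogen), and that change gave a 1.3-fold higher number from compound 3 to compound 1 (0.11 log units; within the scatter). Compound 2 and compound 3 differ in a different place, (methyl in place of hydrogen on an oxygen on an aromatic ring), with a 1.3-fold higher number from compound 2 to compound 3 (0.11 log units; within the scatter).

Compound 4, `COc1cc(-c2nn(-c3cccc(NC(=O)Nc4cccc(C(F)(F)F)c4)c3)cc2-c2ccncc2)ccc1Cl`, is not yet measured. It stands to compound 2 as compound 1 stands to compound 3: the change is 3-(trifluoromethyl)phenyl in place of 3,4-dichlorophenyl on an amide-type nitrogen, the same change, made on the same kind of amide-type nitrogen, only now on the core that carries the methoxy group rather than the hydroxy group. Among the compounds with values here, the one earlier example of this change, from compound 3 to compound 1, stayed within the scatter, so a step of about the same size is expected here, a 1.3-fold higher number from compound 2 to compound 4 (0.11 log units; within the scatter), because compound 2 starts from 931 nM. With one example only, the uncertainty is wide. Compound 4 is therefore expected to give about 1200 nM in this assay, most likely between 600 nM and 2400 nM.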

Compound 4, concentration for 50% growth inhibition: 739 nM
Beside the measured number, compound 4's estimate is 1.6-fold (0.21 log units) above it, and the stated range covers the measured number.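

Putting 3-(trifluoromethyl)phenyl in place of 3,4-dichlorophenyl on the core that carries the methoxy group gave a 1.3-fold lower number from compound 2 to compound 4 (0.10 log units; within the scatter) in this assay, and the two examples of this change agree as far as the scatter allows: the same change on two cores in this assay, a 1.3-fold higher number (0.11 log units; within the scatter) from compound 3 to compound 1 and a 1.3-fold lower number (0.10 log units; within the scatter) from compound 2 to compound 4, 1.6-fold (0.21 log units) apart, within the scatter of two such steps. The other change, methyl in place of hydrogen on the oxygen, gave a 2.1-fold lower number from compound 1 to compound 4 (0.33 log units; beyond the scatter) with the 3-(trifluoromethyl)phenyl group in place, a modest step, yet it too cannot be told apart from its earlier example: the same change on two cores in this assay, a 1.3-fold higher number (0.11 log units; within the scatter) from compound 2 to compound 3 and a 2.1-fold higher number (0.33 log units; beyond the scatter) from compound 4 to compound 1, 1.6-fold (0.21 log units) apart, within the scatter of two such steps. Within the data shown here, this shows that neither change behaved differently on the two cores, but with only two small steps per change, it does not prove that either step carries over reliably, and it gives no rule beyond these four compounds.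

The compounds shown leave open whether the same steps would hold with an amine or a carboxylic acid on the ring attached to the amide-type nitrogen. They also leave open what a longer chain, such as ethyl or propyl, would do on the oxygen.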